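Cytotoxicity on Vero cells: a chloro substituent added

This account rests on a few compounds, and the source may have more. Where it says the series, first, only, none or still open, it means among the compounds named here.

Of the compounds shown here, two have been measured in an ADME assay on Vero cells (Chlorocebus sabaeus) for cytotoxicity, read by MTT assay, with a stated time of 72 h; a lower number here means that less compound is tolerated, a higher number that more compound is tolerated. Compound 1 `Clc1ccc2c(N3CCN(c4ccccc4)CC3)ccnc2c1` gives 179000 nM in this assay. Compound 2 `CNC1=C([N+](=O)[O-])C(c2ccc(N3CCCN(c4ccnc5cc(Cl)ccc45)CC3)cc2)c2ccccc2O1` gives 91400 nM in this assay. The two numbers lie within the scatter of each other, so compound 2 and compound 1 cannot be told apart on this read-out; compound 2 simply carries the smaller of the two figures, and nothing more can be said of the pair.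

Compound 3 `CNC1=C([N+](=O)[O-])C(c2ccc(N3CCCN(c4ccnc5cc(Cl)ccc45)CC3)cc2)c2cc(Cl)ccc2O1` has not yet been measured in this assay. It differs from compound 2 in one place: chloro in place of hydrogen on an aromatic carbon, with the rest of the molecule unchanged. Among the measured compounds shown here, no pair of measured compounds shows what such a change does here, so the direction of the step is open. With only the two figures above to go on, the step from compound 2 to compound 3 is expected to be small, a 1.3-fold lower number from compound 2 to compound 3 (0.12 log units; within the scatter), at or near the scatter of this assay. Compound 3 is therefore estimated at 70000 nM in this assay, within a range from 30000 nM to 160000 nM.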

Compound 3, half-maximal cytotoxic concentration: 77000 nM
Compound 3: the middle estimate sits 1.1-fold (0.04 log units) below what was measured; the range from low to high includes it.
By their numbers in this assay, from the lowest: compounds 3, 2 and 1 (each within the scatter of the next, the first and the last beyond it).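

Among the compounds shown here, with chloro in place of hydrogen on an aromatic carbon of the six-membered aromatic ring of carbon only, meta to a fused ring and para to a fused ring, the pair shows a 1.2-fold lower number from compound 2 to compound 3 (0.07 log units; within the scatter) in this assay, the first reading of this change at this position. The added chlorine, a single heavy atom with no ring, no hydrogen-bond donor or acceptor and no net charge, therefore leaves compound 3 indistinguishable from compound 2 on this read-out, so this one pair gives no sign that the substituent matters here. Nothing available accounts for this outcome, and no cause can be assigned to it.

Going by these compounds, whether a fluoro, a methoxy, an amine or a carboxylic acid on the same aromatic carbon would also stay within the scatter remains open. Also open, on these data alone, is whether chloro on another carbon of that ring, or a second chloro added to compound 3, would give a step that can be told from the scatter.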